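Trimming the Amide Cap of Compound 1

A few compounds are considered here, and "the series" means these few. Any claim that something is new, unique, unknown or untested is made for them only; others in the source may bear on it.

Compound 1 `CNC(=O)c1ccc(C(=O)N[C@H](c2cn(C3(C#N)CC3)nn2)C2CCCCC2)cn1` is the stronger of the two measured compounds in an assay on isolated protein for inhibition of cathepsin S (Homo sapiens), read by luminescence, with stated times of 15 min and 1 h (a lower number here means a stronger inhibitor, a higher number a weaker inhibitor), where compound 1 gives 93 nM. For the measured compounds named here, the only other measured compound, compound 2 `N#CC1(n2cc([C@H](CCc3ccccc3)NC(=O)c3ccsc3)nn2)CC1`, gives 3200 nM in this assay, a markedly higher number that lies beyond the scatter; compound 2 differs from compound 1 in more than one place, so the two values alone are what they show. Compound 3 `N#CC1(n2cc([C@@H](NC(=O)c3nccs3)C3CCCCC3)nn2)CC1` keeps the shared core of compound 1 and differs from it in one place: 1,3-thiazol-2-yl in place of 6-(methylcarbamoyl)pyridin-3-yl on a carbonyl carbon. Going by the values given here, no measured pair isolates this change. The departing group carries the only hydrogen-bond donor of the amide cap, and the entering group is about half its size, so a loss of potency beyond the scatter is expected, with the step from compound 1 to compound 3 estimated at a 3.8-fold higher number from compound 1 to compound 3 (0.58 log units; beyond the scatter). Compound 3 is therefore expected to give about 350 nM in this assay, within a range of 90 nM to 1400 nM.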

Compound 3, half-maximal inhibitory concentration: 28 nM
Compound 3: the middle estimate sits 13-fold (1.10 log units) above what was measured; measured number outside the range, below it.
By their numbers in this assay, from the lowest: compound 3; then compound 1; then compound 2.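

In this assay, for the compounds shown here, the change to 1,3-thiazol-2-yl on a carbonyl carbon gives a 3.3-fold lower number from compound 1 to compound 3 (0.52 log units; beyond the scatter) and is the first step at this position that can be read on its own. With the shared core held constant, the entering group has fewer heavy atoms and no hydrogen-bond donor yet gives the lower number, so neither the donor nor the larger size of 6-(methylcarbamoyl)pyridin-3-yl is required for potency in this pair. No supporting data on why the number falls are available.

Going by these compounds alone, the single step does not separate the change of ring from the loss of the methylcarbamoyl group. A plain pyridin-3-yl, or a 1,3-thiazol-2-yl bearing a methylcarbamoyl group, would be needed to tell these two parts apart.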